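The source may report more compounds than this note shows. Statements on the series, on what has been measured and on what is new or still open speak of the compounds shown alone.

In a functional assay on HeLa cells (Homo sapiens) for cytotoxicity, read by MTT assay (on this read-out lower numbers stand for stronger inhibition and higher numbers for weaker inhibition), compound 1 `CCCCCCC(C)(O)CC(=O)O[C@H](CC=C(C)C)C1=CC(=O)c2c(O)ccc(O)c2C1=O` gives > 100000 nM, which is a limit of the assay and not a number. Among the measured compounds shown here, compound 2 `CCCC(CC(=O)O[C@H](CC=C(C)C)C1=CC(=O)c2c(O)ccc(O)c2C1=O)OC(C)=O` gives 51200 nM, the only actual number available so far, so it cannot yet be ranked against a second measured value. For the measured compounds named here, the one measured step, an at least 1.9-fold lower number from compound 1 to compound 2 (0.29 log units; that floor lies within the scatter), starts from that limit, and its floor lies within the scatter. It therefore offers no firm size for what comes next. Compound 3 `CC(C)=CC[C@@H](OC(=O)CC(O)c1ccccc1)C1=CC(=O)c2c(O)ccc(O)c2C1=O` keeps the shared core and changes one group: hydroxy(phenyl)methyl in place of 1-acetoxybutyl on a saturated chain carbon bound to a carbonyl carbon. In words, hydroxy(phenyl)methyl takes the place of 1-acetoxybutyl on a saturated chain carbon bound to a carbonyl carbon. With so little to go on, the expected change, a 1.5-fold lower number from compound 2 to compound 3 (0.17 log units; within the scatter), is none beyond the scatter. For compound 3 the estimated value is 35000 nM, with an expected range from 9000 nM to 100000 nM.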

Compound 3, half-maximal inhibitory concentration: 44500 nM
Compound 3: middle estimate off by 1.3-fold (0.10 log units), on the low side; low and high end bracket the measured number.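

With hydroxy(phenyl)methyl in place of 1-acetoxybutyl on a saturated chain carbon bound to a carbonyl carbon, the step in this assay reads a 1.2-fold lower number from compound 2 to compound 3 (0.06 log units; within the scatter), so the two groups cannot be told apart here, although only the entering one carries a six-membered aromatic ring. The step that starts from a limit, an at least 2.2-fold lower number from compound 1 to compound 3 (0.35 log units; beyond the scatter), is the first shown to clear the scatter, yet it gives only a floor and no exact size. That limit also restricts what this small set can show: the limit of > 100000 nM in this assay, at which 1 of the 3 values shown sits.

The compounds shown do not separate the contribution of the hydroxy group from that of the phenyl ring in hydroxy(phenyl)methyl. On these data alone, how an amine or a carboxylic acid in the same place would read also remains open.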